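This account rests on a few compounds, and the source may have more. Where it says the series, first, only, none or still open, it means among the compounds named here.

Measured so far:
compound 1 `O=C(Oc1ccccc1OC(=O)c1ccc(O)cc1)c1ccc(O)cc1` — 57.5%
compound 2 `O=C(Oc1ccc(Cl)cc1OC(=O)c1cccc(O)c1)c1cccc(O)c1` — 93.1%

In a functional assay on NCI-H1299 cells (Homo sapiens) for inhibition, read by scintillation counting, with a stated time of 30 min, tested at 30 uM (a lower number here means less inhibition, a higher number more inhibition at the concentration tested (going by the name of the read-out)), compound 2 gives 93.1%, the highest of the two numbers. Compound 1 gives 57.5% in this assay, a gap beyond the scatter. Compound 3 `O=C(Oc1ccc(F)cc1OC(=O)c1cccc(O)c1)c1cccc(O)c1` is not yet measured. It differs from compound 2 by fluoro in place of chloro on an aromatic carbon. Among the measured compounds shown here, no step between measured compounds shows what such a change does here, so the expected step is a number 7.1 percentage points lower from compound 2 to compound 3 (within the scatter), none beyond the scatter, leaning slightly lower. Compound 3 is expected to give 86% in this assay, with a range from 66% to 98%.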

Compound 3, a percentage reported as inhibition, at one concentration (the size of the read-out at that concentration, not a potency): 92.8%
Beside the measured number, compound 3's estimate is 6.8 percentage points below it, within the range that was stated.
By their numbers in this assay, from the lowest: compound 1; then compounds 3 and 2 (each within the scatter of the next).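

Fluoro in place of chloro on this aromatic carbon, meta to a large group and para to a large group, now has a measured step in this assay and comes to a number 0.3 percentage points lower from compound 2 to compound 3 (within the scatter) so the two halogens cannot be told apart at this position in this read-out. The earlier compounds shown here held no step of this kind. Nothing measured here offers an explanation for this result.

As far as these compounds go, what an amine, a methoxy group or a carboxylic acid would give at this position remains open. So does the effect of leaving this aromatic carbon with hydrogen alone, with no halogen on it.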